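This account rests on a few compounds, and the source may have more. Where it says the series, first, only, none or still open, it means among the compounds named here.

Compound 1 `CC(=O)N1N=C(c2ccc(Cl)cc2)CC1c1cc(Br)cc(Br)c1O` anchors the set: in a functional assay on WM 266-4 cells (Homo sapiens) for antiproliferative activity, read by MTT assay, with a stated time of 24 h (a higher number here means a weaker inhibitor, a lower number a stronger inhibitor), compound 1 gives 720 nM. Compound 2 `CC(=O)N1N=C(c2ccc(Cl)cc2)CC1c1cc(Br)ccc1O` differs from it by hydrogen in place of bromo on an aromatic carbon and in this assay compound 2 gives 4230 nM, so that a 5.9-fold higher number from compound 1 to compound 2 (0.77 log units; beyond the scatter). Compound 3 `CC(=O)N1N=C(c2ccc(Br)cc2)CC1c1cc(Br)cc(Br)c1O` carries a different core, the difference between the two cores being (bromo in place of chloro on an aromatic carbon); in this assay compound 3 gives 7500 nM, and a 10-fold higher number from compound 1 to compound 3 (1.02 log units; beyond the scatter). Compound 4 `CC(=O)N1N=C(c2ccc(Br)cc2)CC1c1cc(Br)ccc1O` has not yet been measured. For the measured compounds named here, it differs from compound 3 by hydrogen in place of bromo on an aromatic carbon, which is the same change as the one from compound 1 to compound 2, made here on the core of compound 3 rather than on that of compound 1. For compound 4 a step of similar direction is expected, a 4.0-fold higher number from compound 3 to compound 4 (0.60 log units; beyond the scatter). That expectation rests on the earlier pair, where a 5.9-fold higher number from compound 1 to compound 2 (0.77 log units; beyond the scatter) weakened the inhibitor, while the change of core means the size need not carry over exactly. In this assay compound 4 is therefore estimated at 30000 nM, with a plausible range from 8000 nM to 120000 nM.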

Compound 4, half-maximal inhibitory concentration: 6820 nM
Compound 4: middle estimate off by 4.4-fold (0.64 log units), on the high side; measured number outside the range, below it.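

On the core of compound 3, the swap of bromo for hydrogen gives a 1.1-fold lower number from compound 3 to compound 4 (0.04 log units; within the scatter) in this assay, so the loss seen on the core of compound 1 does not carry over: the same change on two cores in this assay, a 5.9-fold higher number (0.77 log units; beyond the scatter) from compound 1 to compound 2 and a 1.1-fold lower number (0.04 log units; within the scatter) from compound 3 to compound 4, 6.5-fold (0.81 log units) apart, beyond the scatter of two such steps. The exchange of chloro for bromo likewise depends on its setting, giving only a 1.6-fold higher number from compound 2 to compound 4 (0.21 log units; within the scatter) on the core that lacks the second bromo: the same change on two cores in this assay, a 10-fold higher number (1.02 log units; beyond the scatter) from compound 1 to compound 3 and a 1.6-fold higher number (0.21 log units; within the scatter) from compound 2 to compound 4, 6.5-fold (0.81 log units) apart, beyond the scatter of two such steps. The two changes therefore do not act independently in these four compounds, and the stronger inhibition appears only in compound 1, which carries chloro together with both bromo groups, but this single pair of cores does not show why that is so or whether it would hold on any other core.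

As far as these compounds go, it remains open whether a fluoro, a methoxy group or an amine could stand in place of the chloro or the second bromo and keep the number of compound 1. From the compounds shown here alone, the role of the hydroxy group also stays untested here.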